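This account rests on a few compounds, and the source may have more. Where it says the series, first, only, none or still open, it means among the compounds named here.

Measured so far:
- Compound 1 `CO[C@@H]1[C@H]2OC(=O)C[C@H]2O[C@@H]1[C@@H](O)c1ccccc1`: > 100000 nM
- Compound 2 `O=C1C[C@H]2O[C@H](C(O)O)[C@H](O)[C@H]2O1`: > 100000 nM
- Compound 3 `CO[C@@H]1[C@H]2OC(=O)C[C@H]2O[C@@H]1C(O)(c1ccccc1)c1ccccc1`: > 100000 nM

In an ADME assay on MRC5 cells (Homo sapiens) for inhibition, read by MTT assay, with a stated time of 72 h (a lower number here means a stronger inhibitor, a higher number a weaker inhibitor), compound 1 gives > 100000 nM, which is a limit of the assay and not a number. The other two compounds give the same kind of result, so the picture is the limit of > 100000 nM in this assay, at which 3 of the 3 values shown sit. Compound 4 `CO[C@@H]1[C@H]2OC(=O)C[C@H]2O[C@@H]1[C@H](O)c1ccccc1` changes compound 1 in one respect: the two compounds have the same atoms and bonds and differ only in configuration as drawn: 1 of 5 stereo elements differ; a stereocentre at a saturated chain carbon is drawn S in compound 1 and R in compound 4. Within the data shown here, no measured pair shows what such a change does, and none of the three compounds has given an actual number. The expectation in this assay is therefore no step beyond the usual scatter, and the estimated change is a number no higher from compound 1 to compound 4 (the limit leaves the size open). For compound 4 the expected value is 100000 nM, with an estimated range of 30000 nM to 150000 nM.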

Compound 4, half-maximal inhibitory concentration: > 100000 nM
Compound 4 ended at the assay's limit; the forecaster's own chance of this, stated with the estimate: 80%; the middle value lies on the limit itself.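

No step can be read from compound 1 to compound 4, as both values are limits of the assay and not numbers: the limit of > 100000 nM in this assay, at which 4 of the 4 values shown sit.

The compounds shown leave open whether this single change of configuration has any effect, and what value any of them would reach beyond the limit.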